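From Dichloro to Difluoro: One Cytotoxicity Step Ahead

The source may hold more compounds than are shown below. What is called first, only, known or untested is meant among the compounds shown, and "the series" means these compounds.

compound 1 `COc1ccc(-c2cc(/C=C/C(=O)c3ccc(N)cc3)[nH]n2)cc1`: 101%
compound 2 `COc1cc(-c2cc(/C=C/C(=O)c3ccc(Cl)c(Cl)c3)[nH]n2)cc(OC)c1OC`: 100%

In a functional assay on NCI/ADR-RES cells (Homo sapiens) for cytotoxicity, read by sulforhodamine B assay, with a stated time of 48 h, tested at 0.01 uM (a higher number here means a weaker effect of the compound at the concentration tested, a lower number a stronger effect), compound 1 gives 101%. In this assay compound 2 gives 100%. Compound 2 and compound 1 lie within the usual scatter of each other, and neither shows an effect beyond that scatter at this concentration.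

Compound 3 `COc1cc(-c2cc(/C=C/C(=O)c3ccc(F)c(F)c3)[nH]n2)cc(OC)c1OC` has not yet been measured. It differs from compound 2 by 3,4-difluorophenyl in place of 3,4-dichlorophenyl on a carbonyl carbon. For the measured compounds named here, no step between two measured compounds is known here, so no step beyond the scatter is expected.

Compound 3 is expected to give about 100%, estimated between 88% and 110%. The step of no change at the digits printed from compound 2 to compound 3 (within the scatter) is expected to stay within the scatter.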

Compound 3, a percentage reported as activity, at one concentration (the size of the read-out at that concentration, not a potency): 100%
Compound 3: middle estimate and measured number agree at the digits printed; low and high end bracket the measured number.
By their numbers in this assay, from the lowest: compounds 2, 3 and 1 (each within the scatter of the next).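

In this assay, for the compounds shown here, 3,4-difluorophenyl in place of 3,4-dichlorophenyl on a carbonyl carbon gives no change at the digits printed from compound 2 to compound 3 (within the scatter) as the first comparison of compounds differing in one place. At this concentration, then, the read-out does not tell these two groups apart. Nothing available here offers an explanation for this result.

As far as these compounds go, whether a different group on this carbonyl carbon, such as a pyridine ring or a carboxylic acid on the phenyl ring, would move the read-out stays open. Also open, from the compounds shown here alone, is whether compound 2 and compound 3 would separate at a higher concentration.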